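The compounds below may be only part of what the source reports. "The series", "measured", "known", "first", "only" and "open" are said of these compounds alone.

Compound 1 `COc1cc(-c2ncnn2-c2cccc(N)c2)cc(OC)c1OC` gives no number to build on. In a functional assay on Jurkat cells (Homo sapiens) for antiproliferative activity, read by MTT assay, with a stated time of 72 h (on this read-out higher numbers stand for weaker inhibition and lower numbers for stronger inhibition), compound 1 gives > 10000 nM, which is a limit of the assay and not a number. That places it at the limit of > 10000 nM in this assay, at which 1 of the 2 values shown sits. The other value comes from compound 2 `CCOc1ccc(-c2ncnn2-c2cc(OC)c(OC)c(OC)c2)cc1`, which differs from compound 1 in more than one place. In this assay compound 2 gives 5 nM, so strong inhibition is possible among these close relatives, although this pair does not isolate any single change.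

Compound 3 `COc1cc(-c2ncnn2-c2ccc(Cl)c(Cl)c2)cc(OC)c1OC` keeps the core of compound 1 and carries 3,4-dichlorophenyl in place of 3-aminophenyl on an aromatic nitrogen. Within the data shown here, no measured pair shows what this swap does, so any forecast is uncertain. Compound 3 shares its core with compound 1, so the estimate starts from compound 1, whose > 10000 nM is again a limit. The expected change, an at least 3.3-fold lower number from compound 1 to compound 3 (0.52 log units; beyond the scatter), is a modest move towards stronger inhibition in this assay, and another limit would be no surprise. For compound 3 the estimated value is 3000 nM, with an expected range from 300 nM to 10000 nM.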

Compound 3, half-maximal inhibitory concentration: > 10000 nM
Compound 3: a limit, no number (the forecaster's own chance of this, stated with the estimate: 45%); at least 3.3-fold (0.52 log units) between middle value and limit.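

In this assay compound 3 gives > 10000 nM, which is a limit of the assay and not a number. Among these compounds, compound 1 also stands at a limit, so no step from compound 1 to compound 3 can be read: the limit of > 10000 nM in this assay, at which 2 of the 3 values shown sit. The compounds shown leave open whether 3,4-dichlorophenyl or 3-aminophenyl on that aromatic nitrogen gives stronger inhibition.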